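A few compounds are considered here, and "the series" means these few. Any claim that something is new, unique, unknown or untested is made for them only; others in the source may bear on it.

Measured compounds:
- compound 1, `C=CCN(C)C(=O)c1ccc(C(CC)(CC)c2ccc(OCC(=O)C(C)(C)C)c(C)c2)n1CC`: 21600 nM
- compound 2, `CCN(CC)CCCNC(=O)c1ccc(C(CC)(CC)c2ccc(OCC(O)C(C)(C)C)c(C)c2)n1CC`: 66 nM
- compound 3, `C=CCN(C)C(=O)c1ccc(C(CC)(CC)c2ccc(OCC(O)C(C)(C)C)c(C)c2)n1CC`: 3950 nM

In an assay on HL-60 cells for agonist activity at vitamin D3 receptor (Homo sapiens), read by microscopy, with a stated time of 96 h (a higher number here means that more compound is needed for the effect, a lower number that less compound is needed), compound 1 gives the highest number of the three. Its nearest neighbour is compound 3, which shares the same amide and differs only in the side chain on the aromatic oxygen; that step, a 5.5-fold lower number from compound 1 to compound 3 (0.74 log units; beyond the scatter), is modest. Compound 2 lies furthest from compound 1, and the step of a 60-fold higher number from compound 2 to compound 3 (1.78 log units; beyond the scatter) shows that the group on the carbonyl carbon can move the number a long way.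

Compound 4, `CCn1c(C(=O)Nc2ccc(OC(F)(F)F)cc2)ccc1C(CC)(CC)c1ccc(OCC(=O)C(C)(C)C)c(C)c1`, is still to be measured. It differs from compound 1 only at the carbonyl carbon: (4-(trifluoromethoxy)phenyl)amino in place of allyl(methyl)amino on a carbonyl carbon. Within the data shown here, no measured pair tests this exact exchange. Among the measured compounds shown here, the only step at the same position, a 60-fold higher number from compound 2 to compound 3 (1.78 log units; beyond the scatter), went between two amines of quite different kind, so its size is a rough guide rather than a template. The entering group brings one hydrogen-bond donor, as compound 2 also carries at the carbonyl, which argues for a lower number for compound 4, though the measured steps do not fix its size.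

Compound 4 is therefore expected to show a lower number than compound 1, a step estimated as a 5.4-fold lower number from compound 1 to compound 4 (0.73 log units; beyond the scatter). The estimate for compound 4 in this assay is 4000 nM, with a range from 700 nM to 22000 nM.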

Compound 4, half-maximal effective concentration: > 50000 nM
Compound 4: a limit, no number; the forecaster's own chance of this, stated with the estimate: 10%; at least 12-fold (1.09 log units) between middle value and limit.
By their numbers in this assay, from the lowest: compound 2; then compound 3; then compound 1. At a limit, above all of these: compound 4.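

In this assay compound 4 gives > 50000 nM, which is a limit of the assay and not a number. The step of an at least 2.3-fold higher number from compound 1 to compound 4 (0.36 log units; beyond the scatter) shows that a change on the carbonyl carbon can raise the number on this core, while the only earlier step at this place, a 60-fold higher number from compound 2 to compound 3 (1.78 log units; beyond the scatter), had shown only that an amine with the amide hydrogen can stand on the low side of one without it, and here an entering group with a hydrogen-bond donor brought no lower number. How large the rise really is stays unread: the limit of > 50000 nM in this assay, at which 1 of the 4 values shown sits.

On these data alone, it remains open whether the aromatic ring itself or the trifluoromethoxy group on it goes with this rise, which a plain phenylamino or a benzylamino group on the carbonyl carbon could separate. Also open, as far as these compounds go, is whether (4-(trifluoromethoxy)phenyl)amino behaves the same way alongside the 1-hydroxy-2,2-dimethylpropyl side chain.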